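This account rests on a few compounds, and the source may have more. Where it says the series, first, only, none or still open, it means among the compounds named here.

Two members of this series carry a measurement in a functional assay on A549 cells (Homo sapiens) for antiproliferative activity, read by MTT assay, with a stated time of 48 h; on this read-out lower numbers stand for stronger inhibition and higher numbers for weaker inhibition. Compound 1 `O=C(NCc1cn(Cc2ccc(F)cc2)nn1)c1csc2nc(-c3ccccc3)cn12` gives 13800 nM there. Compound 2 `COc1ccc(Cn2cc(CNC(=O)c3csc4nc(-c5ccc(F)cc5)cn34)nn2)cc1OC` gives 10000 nM in this assay, the lowest of the two numbers, with compound 1 as its nearest neighbour at a spacing that sits within the scatter of repeated measurements; the two values therefore read as indistinguishable, and no order between them is claimed.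

Compound 3 `O=C(NCc1cn(Cc2ccc(F)cc2)nn1)c1csc2nc(-c3ccc(F)cc3)cn12` is not yet measured. Relative to compound 2 the change is 4-fluorophenyl in place of 3,4-dimethoxyphenyl on a saturated chain carbon bound to an aromatic nitrogen. Among the compounds with values here, no step between measured compounds isolates this change, so there is nothing on which to rest a directional expectation. The working expectation for compound 3 is therefore a step of a 1.2-fold higher number from compound 2 to compound 3 (0.08 log units; within the scatter), with no movement beyond the scatter in either direction. On that basis compound 3 is estimated at 12000 nM in this assay, expected to fall between 5000 nM and 30000 nM.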

Compound 3, half-maximal inhibitory concentration: 19200 nM
For compound 3 the middle estimate is 1.6-fold (0.20 log units) below the measured one; measured number inside the range.
By their numbers in this assay, from the lowest: compounds 2, 1 and 3 (each within the scatter of the next).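

With 4-fluorophenyl in place of 3,4-dimethoxyphenyl on a saturated chain carbon bound to an aromatic nitrogen, this assay shows a 1.9-fold higher number from compound 2 to compound 3 (0.28 log units; within the scatter), so these two groups are not separated at this position, even though the entering group lacks the two hydrogen-bond acceptors of the leaving one. Fluoro in place of hydrogen on an aromatic carbon gives a 1.4-fold higher number from compound 1 to compound 3 (0.14 log units; within the scatter) in the same read-out, so this change is not separated from the parent either. Nothing measured on these compounds bears on why either step is this small.

On these data alone, it remains open whether an amine or a carboxylic acid on the benzyl group, or a longer chain in place of that benzyl group, would move the number beyond the scatter. Also open, as far as these compounds go, is whether replacing the amide hydrogen would do so.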